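From 3-nitrophenyl to pyridin-4-yl on the shared core

The source may report more compounds than this note shows. Statements on the series, on what has been measured and on what is new or still open speak of the compounds shown alone.

In a functional assay on MCF7 cells (Homo sapiens) for cytotoxicity, read by MTT assay, with a stated time of 48 h (on this read-out lower numbers stand for stronger inhibition and higher numbers for weaker inhibition), compound 1 `CC(C)=CCC/C(C)=C/CC/C(C)=C/CC[C@@H]1[C@@]2(C)CC/C(=N\OCc3cn(-c4ccc(Cl)cc4)nn3)C(C)(C)[C@@H]2CC[C@@]1(C)O` gives 12400 nM, and compound 2 `CC(C)=CCC/C(C)=C/CC/C(C)=C/CC[C@@H]1[C@@]2(C)CC/C(=N\OCc3cn(-c4cccc([N+](=O)[O-])c4)nn3)C(C)(C)[C@@H]2CC[C@@]1(C)O` gives 20700 nM. Compound 2 thus stands within the scatter of compound 1, and the two numbers cannot be ranked. Compound 3 `CC(C)=CCC/C(C)=C/CC/C(C)=C/CC[C@@H]1[C@@]2(C)CC/C(=N\OCc3cn(-c4ccncc4)nn3)C(C)(C)[C@@H]2CC[C@@]1(C)O` keeps the shared core and differs from compound 2 in one group: pyridin-4-yl in place of 3-nitrophenyl on an aromatic nitrogen. Pyridin-4-yl comes in place of 3-nitrophenyl on an aromatic nitrogen of a five-membered aromatic ring with 3 nitrogen. Going by the values given here, only one measured step bears on this exchange, a 1.7-fold higher number from compound 1 to compound 2 (0.22 log units; within the scatter), which also replaces the group at this place and stays within the scatter. On that single step, no change beyond the scatter is expected in this assay, and the expected step is a 1.2-fold lower number from compound 2 to compound 3 (0.06 log units; within the scatter). For compound 3 the estimated value is 18000 nM, with an expected range from 8000 nM to 45000 nM.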

Compound 3, half-maximal inhibitory concentration: 12600 nM
Compound 3: the middle estimate sits 1.4-fold (0.15 log units) above what was measured; the measured number falls inside the stated range.
By their numbers in this assay, from the lowest: compounds 1, 3 and 2 (each within the scatter of the next).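

The earlier compounds shown here carried only a six-membered aromatic ring of carbon on this aromatic nitrogen, whereas compound 3 places a ring with 1 hetero atom there. In this assay the exchange from 3-nitrophenyl gives a 1.6-fold lower number from compound 2 to compound 3 (0.22 log units; within the scatter) and the exchange from 4-chlorophenyl gives a 1.0-fold higher number from compound 1 to compound 3 (0.01 log units; within the scatter) so that 4-chlorophenyl, 3-nitrophenyl and pyridin-4-yl cannot be ranked at this position, and the hetero atom in the ring brings no change that can be read. No measurement is at hand that would explain this result.

Still open, as far as these compounds go, is whether any group on this nitrogen moves the number beyond the scatter. A saturated chain such as butyl, or a phenyl ring bearing an amine or a carboxylic acid, might answer that, and the three compounds give no indication either way.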